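Chloro Placement and Whole-Plant Activity: Forecasting Compound 3

This account rests on a few compounds, and the source may have more. Where it says the series, first, only, none or still open, it means among the compounds named here.

Measured so far:
compound 1, `C[C@@H](NC(=O)Nc1ccccc1Cl)c1ccccc1`: 101%
compound 2, `C[C@@H](NC(=O)Nc1ccc(Cl)cc1Cl)c1ccccc1`: 101%

The study concerns a pair of compounds that share one core and differ only in the pattern of chloro groups on one aromatic ring. In an ADME assay on the whole organism with Oryza sativa as the target, tested at 0.1 uM (a higher number here means a weaker effect of the compound at the concentration tested, a lower number a stronger effect), compound 1 gives 101%. Compound 2 gives 101% in this assay. The step of no change at the digits printed from compound 1 to compound 2 (within the scatter), where a chloro replaces a hydrogen on an aromatic carbon, leaves the read-out where it was. Compound 1 therefore stands level with compound 2 at the digits shown, and nothing separates the two beyond the usual scatter.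

Compound 3, `C[C@@H](NC(=O)Nc1cc(Cl)ccc1Cl)c1ccccc1`, is not yet measured. It differs from compound 1 as follows: chloro in place of hydrogen on an aromatic carbon. Within the data shown here, the only measured step that bears on this change is no change at the digits printed from compound 1 to compound 2 (within the scatter), which made the same kind of exchange on the same ring and moved nothing. On that basis the step of a number 1 percentage points lower from compound 1 to compound 3 (within the scatter) is expected to stay within the scatter. Compound 3 is thus estimated to give 100% in this assay, with a range from 88% to 108%.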

Compound 3, a percentage reported as activity, at one concentration (the size of the read-out at that concentration, not a potency): 99%
Compound 3: middle estimate off by 1 percentage points, on the high side, and the stated range covers the measured number.
By their numbers in this assay, from the lowest: compounds 3, 1 and 2 (each within the scatter of the next).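

In this assay, a chloro entering on an aromatic carbon, at a place meta to a large group and para to a chloro group, gives a number 2 percentage points lower from compound 1 to compound 3 (within the scatter), so this second position on the ring also shows no measurable response to the exchange. Taken with no change at the digits printed from compound 1 to compound 2 (within the scatter), the result means that the same exchange of hydrogen for chloro has now been read at two different places on one ring, and neither step moves the read-out beyond the scatter at the single concentration tested. Nothing available speaks to why the read-out stays flat at either place.

The compounds shown leave open whether a group other than chloro at this place, such as an amine, a carboxylic acid or a methoxy group, would shift the read-out beyond the scatter. They also leave open whether a change elsewhere on the shared core, such as a longer chain in place of the methyl group, would separate any compound from compound 1 in this assay.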